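A few compounds are considered here, and "the series" means these few. Any claim that something is new, unique, unknown or untested is made for them only; others in the source may bear on it.

Series notes. Two compounds of the shared core have numbers in a functional assay on mitochondria (Cricetulus griseus) for inhibition of Monoamine oxidase (Homo sapiens), tested at 9 uM; a higher number here means a stronger effect of the compound at the concentration tested, a lower number a weaker effect. Compound 1 `O=c1c(-c2ccc(O)cc2)coc2cc(OCCCBr)ccc12` gives 100%. Within the data shown here, compound 2 `O=c1c(-c2ccc(O)cc2)coc2cc(OCC(O)CO)ccc12` gives 95.1%, and the only comparison available is a number 4.9 percentage points lower from compound 1 to compound 2 (within the scatter), so the two numbers sit together inside the scatter, both close to the top of the inhibition scale. Compound 3 `O=C(O)CCCCCCOc1ccc2c(=O)c(-c3ccc(O)cc3)coc2c1` is not yet measured. It differs from compound 2 by 5-carboxypentyl in place of 1,2-dihydroxyethyl on a saturated chain carbon bound to an oxygen on an aromatic ring. Among the measured compounds shown here, one measured step bears on this position: a number 4.9 percentage points lower from compound 1 to compound 2 (within the scatter), where an exchange on the same saturated chain carbon bound to an oxygen on the aromatic ring left the read-out where it was. For the measured compounds named here, with that as the only guide, no movement beyond the scatter is expected, and the next step is estimated as a number 3.1 percentage points lower from compound 2 to compound 3 (within the scatter). For compound 3 the expected value is 92%, with a range from 78% to 100%.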

Compound 3, a percentage reported as inhibition, at one concentration (the size of the read-out at that concentration, not a potency): 94.6%
The estimate for compound 3 lay 2.6 percentage points below the measured number, and the stated range covers the measured number.
By their numbers in this assay, from the lowest: compounds 3, 2 and 1 (each within the scatter of the next).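

In this assay, the read-out does not separate 5-carboxypentyl from 1,2-dihydroxyethyl on a saturated chain carbon bound to an oxygen on an aromatic ring, with a number 0.5 percentage points lower from compound 2 to compound 3 (within the scatter). Set against the bromo end, 3-carboxypropyl in place of bromo on a saturated chain carbon, three bonds along the chain from an oxygen on an aromatic ring, gives a number 5.4 percentage points lower from compound 1 to compound 3 (within the scatter), so the longer chain ending in a carboxylic acid joins the other two compounds near the top of the scale, and this position has now taken three different chain ends without a step beyond the scatter. No measurement shown here offers an explanation for this.

With all three numbers so close to the top of the scale, a read-out at a single concentration cannot show whether potency differs among them. From the compounds shown here alone, how a chain ending in an amine or a ring would read at this position remains open.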